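This account rests on a few compounds, and the source may have more. Where it says the series, first, only, none or still open, it means among the compounds named here.

Working notes on the diaryl semicarbazone series in a functional assay on the whole organism with Mus musculus as the target, with a stated time of 1 h; on this read-out higher numbers stand for an effect only at larger amounts of compound and lower numbers for an effect already at smaller amounts.

Going by the values given here, compound 1 `NC(=O)N/N=C\c1ccc(Oc2cccc(F)c2F)cc1` is the first member. In this assay compound 1 reaches only a limit of the assay, > 350 mg/kg. Compound 2 `CCCc1ccc(Oc2ccc(/C=N/NC(N)=O)cc2)cc1` carries a propyl group on the outer ring instead. In this assay, among the compounds with values here, compound 2 gives 79.6 mg/kg, the single numeric value in the set so far. Compound 3 `NC(=O)N/N=C/c1ccc(Sc2ccccc2)cc1` replaces the ether bridge by a thioether. In this assay compound 3 likewise shows only a limit, > 46 mg/kg, and not a number. Where compound 3 stands is thus open: of the three values shown, two are limits (the limit of > 350 mg/kg in this assay, at which 1 of the 3 values shown sits, and (the limit of > 46 mg/kg in this assay, at which 1 of the 3 values shown sits)), and no step between any pair of measured compounds can be computed.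

Compound 4 `NC(=O)N/N=C/c1ccc(Sc2ccc(F)cc2)cc1` differs from compound 3 by a single change, (fluoro in place of hydrogen on an aromatic carbon), a fluoro in place of hydrogen on an aromatic carbon. Within the data shown here, with no measured step to lean on, the step from compound 3 to compound 4 is expected to stay within the scatter of this assay, in either direction at most modestly, estimated as a step that the limit leaves unreadable from compound 3 to compound 4. For compound 4 the expected dose for half-maximal effect is 70 mg/kg, estimated to fall between 30 mg/kg and 200 mg/kg, with a fair chance that the assay again reports only a limit.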

Compound 4, dose for half-maximal effect: > 120 mg/kg
Compound 4: no number, only a limit; the forecaster's own chance of this, stated with the estimate: 45%; middle value at least 1.7-fold (0.23 log units) from the limit.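

In this assay compound 4 again gives only a limit, > 120 mg/kg. Compound 3 also stands at a limit, so no step can be read from compound 3 to compound 4. The compounds shown leave open whether fluoro in place of hydrogen on an aromatic carbon changes the dose for half-maximal effect at all.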